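Bromo Substitution on Two Related Cytotoxic Cores

The compounds below may be only part of what the source reports. "The series", "measured", "known", "first", "only" and "open" are said of these compounds alone.

Measured compounds:
compound 1, `O=C1N=C(N2N=C(c3ccccc3)CC2c2ccccc2O)S/C1=C1/C(=O)Nc2ccccc21`: 2030 nM
compound 2, `O=C1N=C(N2N=C(c3ccccc3)CC2c2ccccc2O)S/C1=C1/C(=O)Nc2ccc(Br)cc21`: 240 nM
compound 3, `COc1ccc(C2CC(c3ccc4ccccc4c3)=NN2C2=NC(=O)/C(=C3\C(=O)Nc4ccccc43)S2)cc1`: 620 nM

All three compounds were tested in a functional assay on cells (Cancer cell lines, Homo sapiens) for cytotoxicity, read by sulforhodamine B assay, with a stated time of 48 h; on this read-out lower numbers stand for stronger inhibition of growth and higher numbers for weaker inhibition of growth. In this assay compound 1 gives 2030 nM, and compound 2 gives 240 nM. The two differ in only one place: bromo in place of hydrogen on an aromatic carbon. That single change made an 8.5-fold lower number from compound 1 to compound 2 (0.93 log units; beyond the scatter), so the brominated compound 2 inhibits growth markedly more strongly than compound 1.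

Compound 3 is built on a different core, and in this assay compound 3 gives 620 nM. The difference between the core of compound 1 and the core of compound 3 is not broken down here; the two differ in more than one place. Among the three measured compounds, compound 3 sits between the other two, with compound 2 giving the lower number and compound 1 the higher one.

Compound 4, `COc1ccc(C2CC(c3ccc4ccccc4c3)=NN2C2=NC(=O)/C(=C3\C(=O)Nc4ccc(Br)cc43)S2)cc1`, has not yet been measured. It relates to compound 3 exactly as compound 2 relates to compound 1: bromo in place of hydrogen on an aromatic carbon. The place where the bromo enters is described in the same words for both pairs, so this is the same change on a second core.

For compound 4 in this assay a step of a 4.1-fold lower number from compound 3 to compound 4 (0.62 log units; beyond the scatter) is expected, somewhat smaller than the measured step from compound 1 to compound 2, because that earlier step, an 8.5-fold lower number from compound 1 to compound 2 (0.93 log units; beyond the scatter), rests on a single pair and a change of core may shift how much the bromo contributes. Compound 4 is therefore estimated at 150 nM, with a likely range from 50 nM to 400 nM.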

Compound 4, concentration for 50% growth inhibition: 54 nM
Compound 4: the middle estimate sits 2.8-fold (0.44 log units) above what was measured; measured number inside the range.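

In this assay, putting bromo in place of hydrogen on the second core gave an 11-fold lower number from compound 3 to compound 4 (1.06 log units; beyond the scatter), and this step can be set directly beside the one seen on the first core: the same change on two cores in this assay, an 8.5-fold lower number (0.93 log units; beyond the scatter) from compound 1 to compound 2 and an 11-fold lower number (1.06 log units; beyond the scatter) from compound 3 to compound 4, 1.4-fold (0.13 log units) apart, within the scatter of two such steps

So in these two pairs the change carried over from the core of compound 1 to the core of compound 3 with its size preserved, even though those two cores differ in more than one place. This does not show that bromo would give a similar step on any other core, and two pairs from a single cell-based read-out say nothing about why the change strengthens growth inhibition.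

The compounds shown carry only hydrogen or bromo at this aromatic carbon, so it remains open whether a chloro group, a fluoro group or a nitrile there would give a step of similar size, and so whether bromine itself is needed. From the compounds shown here alone, it also remains open whether bromo on another carbon of the same six-membered ring would do as well, or whether the step depends on this one place.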